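Enone series on a shared core: dropping methoxy groups

This account rests on a few compounds, and the source may have more. Where it says the series, first, only, none or still open, it means among the compounds named here.

Among the compounds with values here, three measured compounds define the series so far. Compound 1 `COc1ccc(-c2cc(/C=C/C(=O)c3cc(OC)c(OC)c(OC)c3)nc3cc(-c4ccccc4)nn23)cc1OC` gives 4700 nM in a functional assay on MDA-MB-231 cells (Homo sapiens) for antiproliferative activity, read by MTT assay, with a stated time of 24 h; on this read-out lower numbers stand for stronger inhibition and higher numbers for weaker inhibition. Compound 2 `COc1ccc(C(=O)/C=C/c2cc(-c3cc(OC)c(OC)c(OC)c3)n3nc(-c4ccccc4)cc3n2)cc1OC` gives 18300 nM in this assay, and compound 3 `COc1ccc(-c2cc(C(=O)/C=C/c3ccc(Cl)cc3)nc3cc(-c4ccccc4)nn23)cc1OC` gives 23700 nM. Among these three numbers compound 2 stands second highest: its nearest neighbour is compound 3, whose number lies within the scatter of compound 2, so the two cannot be ordered; compound 1 is the furthest, with a number lower than compound 2 by a gap beyond the scatter.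

Compound 4 `COc1cc(-c2cc(/C=C/C(=O)c3ccccc3)nc3cc(-c4ccccc4)nn23)cc(OC)c1OC` has not been measured. Relative to compound 2 the change is phenyl in place of 3,4-dimethoxyphenyl on a carbonyl carbon. Within the data shown here, no single-site step between measured compounds is available, so the size of this step has to be guessed. Compound 1, which carries the most methoxy-substituted aryl group on the carbonyl carbon, holds the lowest number, and compound 3, with an unsubstituted-oxygen aryl group, the highest; this is a weak hint, not a rule, since the two also differ elsewhere. The step from compound 2 to compound 4 is therefore expected to be small and, if anything, towards a higher number, a 1.4-fold higher number from compound 2 to compound 4 (0.14 log units; within the scatter). Compound 4 is estimated at 25000 nM in this assay, with a range from 10000 nM to 60000 nM.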

Compound 4, half-maximal inhibitory concentration: 15800 nM
Compound 4: middle estimate off by 1.6-fold (0.20 log units), on the high side; the measured number falls inside the stated range.
By their numbers in this assay, from the lowest: compound 1; then compounds 4, 2 and 3 (each within the scatter of the next).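

In this assay the series now has its first single-place step, a 1.2-fold lower number from compound 2 to compound 4 (0.06 log units; within the scatter), so phenyl and 3,4-dimethoxyphenyl on a carbonyl carbon cannot be told apart on this read-out. Within the data shown here, both methoxy groups of that aryl ring can therefore go without a change this assay can resolve, and the weak link between methoxy groups on this aryl ring and lower numbers finds no support in this pair. Nothing on hand speaks to why this swap leaves the number within the scatter.

Open, from the compounds shown here alone, is whether a different group on the carbonyl carbon, such as a phenyl ring bearing a dimethylamino group or a carboxylic acid, or a saturated cyclohexyl ring, would move the number beyond the scatter. Equally open, going by these compounds, is whether taking the methoxy groups off the aryl ring on the carbonyl carbon of compound 1, which gives 4700 nM, would produce a step as small as this one.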